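The source may hold more compounds than are shown below. What is called first, only, known or untested is meant among the compounds shown, and "the series" means these compounds.

Measured so far in a functional assay on HOS cells (Homo sapiens) for antiproliferative activity, with a stated time of 72 h; a higher number here means a weaker inhibitor, a lower number a stronger inhibitor:
compound 1 `COc1cccc(CNc2ncnc3c2ncn3[C@@H]2O[C@H](CO)[C@@H](O)[C@H]2O)c1` gives > 166000 nM, a limit of the assay
compound 2 `OC[C@H]1O[C@@H](n2cnc3c(NCc4ccc(Cl)c(Cl)c4)ncnc32)[C@H](O)[C@@H]1O` gives > 166000 nM, a limit of the assay

Neither value is a number. Within the data shown here, compound 2 stands only at a limit, and the one further value shown, that of compound 1, is a limit as well (the limit of > 166000 nM in this assay, at which 2 of the 2 values shown sit). Among the measured compounds shown here, the single measured step, a step that the two limits leave unreadable from compound 1 to compound 2, cannot be read because the limit of > 166000 nM in this assay, at which 2 of the 2 values shown sit, holds at both of its ends.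

Compound 3 `Cc1ccc(O)c(CNc2ncnc3c2ncn3[C@@H]2O[C@H](CO)[C@@H](O)[C@H]2O)c1` differs from compound 2 in one place: 2-hydroxy-5-methylphenyl in place of 3,4-dichlorophenyl on a saturated chain carbon bound to a nitrogen on an aromatic ring. For the measured compounds named here, no measured step speaks to the 2-hydroxy-5-methylphenyl group in this assay, so the only bearing fact is that both measured compounds sit at the limit. The step expected from compound 2 to compound 3 in this assay is a step that the limit leaves unreadable from compound 2 to compound 3, nothing readable beyond the scatter. Compound 3 is expected to give about 200000 nM (range 60000 nM to 800000 nM), most likely again reported as a limit.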

Compound 3, half-maximal inhibitory concentration: > 166000 nM
Compound 3 was reported as a limit; the forecaster's own chance of this, stated with the estimate: 80%; the middle value does not contradict the limit.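

Compound 3, like compound 1 and compound 2, stands at a limit in this assay, so no step among these compounds can be read: the limit of > 166000 nM in this assay, at which 3 of the 3 values shown sit.

The compounds shown leave open whether any group at this place on the shared core gives a measurable value, and how the 3-methoxyphenyl, 3,4-dichlorophenyl and 2-hydroxy-5-methylphenyl groups truly compare.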